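Replacing iodo with chloro: what toxicity might follow

The source may hold more compounds than are shown below. What is called first, only, known or untested is meant among the compounds shown, and "the series" means these compounds.

Measured in a functional assay on CCRF-CEM cells (Homo sapiens); on this read-out lower numbers stand for higher toxicity in this test and higher numbers for lower toxicity in this test:
Compound 1 `Cc1cn([C@@H]2O[C@H](CO[Si](C)(C)C(C)(C)C)[C@@]3(OS(=O)(=O)C(Br)=C3N)[C@H]2O[Si](C)(C)C(C)(C)C)c(=O)[nH]c1=O`: 17000 nM
Compound 2 `Cc1cn([C@@H]2O[C@H](CO[Si](C)(C)C(C)(C)C)[C@@]3(OS(=O)(=O)C(I)=C3N)[C@H]2O[Si](C)(C)C(C)(C)C)c(=O)[nH]c1=O`: 4000 nM

Of these two compounds, compound 2 has the lower number, 4000 nM, and is therefore the more toxic in this assay. Compound 3 `Cc1cn([C@@H]2O[C@H](CO[Si](C)(C)C(C)(C)C)[C@@]3(OS(=O)(=O)C(Cl)=C3N)[C@H]2O[Si](C)(C)C(C)(C)C)c(=O)[nH]c1=O` keeps the shared core and changes one group: chloro in place of iodo on a double-bonded ring carbon. In words, this is chloro in place of iodo on a double-bonded ring carbon. Going by the values given here, one measured step bears on this change, because the same carbon changes halogen in a 4.3-fold lower number from compound 1 to compound 2 (0.63 log units; beyond the scatter). That step was modest and went to a lower number on gaining iodo. Among the compounds with values here, no chloro compound has been measured, so the size remains uncertain. Losing iodo is expected to give a step of similar size in the opposite direction, towards a higher number. The expected step is a 5.5-fold higher number from compound 2 to compound 3 (0.74 log units; beyond the scatter). For compound 3 the estimated value is 22000 nM, within an expected range of 7000 nM to 60000 nM.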

Compound 3, half-maximal cytotoxic concentration: 7000 nM
Compound 3: middle estimate off by 3.1-fold (0.50 log units), on the high side; the measured number falls inside the stated range.
By their numbers in this assay, from the lowest: compounds 2 and 3 (each within the scatter of the next); then compound 1.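

In this assay chloro and iodo on this double-bonded ring carbon cannot be told apart, with a 1.8-fold higher number from compound 2 to compound 3 (0.24 log units; within the scatter) lying within the usual scatter. Bromo is the one that stands apart, with a 2.4-fold lower number from compound 1 to compound 3 (0.39 log units; beyond the scatter) lying beyond the scatter, and compound 1 keeps the highest number of the three, meaning the lowest toxicity in this test. The earlier step from bromo to iodo therefore did not mark a steady trend running from chloro through bromo to iodo, and at this position iodo can give way to chloro with no clear change in the number.

From the compounds shown here alone, how fluoro, a methyl or a plain hydrogen on this carbon would compare remains open. No measured information is available to explain why bromo stands apart from the other two halogens.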